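Amine substitution on the shared core: benzoyl to ethyl

The source may hold more compounds than are shown below. What is called first, only, known or untested is meant among the compounds shown, and "the series" means these compounds.

The series rests on a shared core carried by compound 1 `CC[C@H](NC)C(=O)N[C@@H]1C(=O)N2[C@@H](CC[C@@H]1CCN)CC[C@H]2C(=O)NC(c1ccccc1)c1ccccc1` and compound 2 `CC[C@H](NC)C(=O)N[C@@H]1C(=O)N2[C@@H](CC[C@@H]1CCNC(=O)c1ccccc1)CC[C@H]2C(=O)NC(c1ccccc1)c1ccccc1`. In a functional assay on MDA-MB-231 cells (Homo sapiens) for cytotoxicity, read by MTT assay, with a stated time of 96 h (on this read-out lower numbers stand for stronger inhibition and higher numbers for weaker inhibition), compound 1 gives 2300 nM, and in this assay compound 2 gives 210 nM. Within the data shown here, compound 2 stands lowest of the two numbers; the only step so far, an 11-fold lower number from compound 1 to compound 2 (1.04 log units; beyond the scatter), is benzoyl in place of hydrogen on an amine nitrogen.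

Compound 3 `CCNCC[C@H]1CC[C@H]2CC[C@@H](C(=O)NC(c3ccccc3)c3ccccc3)N2C(=O)[C@H]1NC(=O)[C@H](CC)NC` differs from compound 2 in one place: ethyl in place of benzoyl on an amine nitrogen. Among the measured compounds shown here, the single measured step bears on it only indirectly, since it records what the benzoyl brings relative to hydrogen and says nothing of ethyl. Because compound 1 gives 2300 nM without the benzoyl, compound 3 is expected to move back toward that number, giving a 7.1-fold higher number from compound 2 to compound 3 (0.85 log units; beyond the scatter). The estimate for compound 3 in this assay is 1500 nM, with a range from 500 nM to 5000 nM.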

Compound 3, half-maximal inhibitory concentration: 1300 nM
Compound 3: middle estimate off by 1.2-fold (0.06 log units), on the high side; measured number inside the range.
By their numbers in this assay, from the lowest: compound 2; then compounds 3 and 1 (each within the scatter of the next).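

In this assay the step of a 6.2-fold higher number from compound 2 to compound 3 (0.79 log units; beyond the scatter) shows that the benzoyl gain on this amine nitrogen does not carry over to ethyl. The step of a 1.8-fold lower number from compound 1 to compound 3 (0.25 log units; within the scatter) places ethyl level with hydrogen, so compound 1 and compound 3 cannot be told apart here. Among the three compounds, substitution on this nitrogen therefore does not by itself separate a compound from the free amine, and only the benzoyl of compound 2 stands apart.

The compounds shown leave open whether the benzoyl gain rests on its carbonyl, its aromatic ring, or the two together. An acetyl or a benzyl on the same nitrogen would bear on that question, as would a substituted benzoyl. No measurement at hand accounts for the gap between benzoyl and ethyl.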